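Furan-amide series: methoxy for fluoro on the central ring

This account rests on a few compounds, and the source may have more. Where it says the series, first, only, none or still open, it means among the compounds named here.

Two compounds of this series carry a nitrofuran amide on a phenyl ring joined to the shared core. Compound 1 `O=C(Nc1ccc(-c2cnc3cc(N4CCCC4)ccn23)cc1)c1ccc([N+](=O)[O-])o1` bears a pyrrolidine on the core, while compound 2 `COc1ccn2c(-c3ccc(NC(=O)c4ccc([N+](=O)[O-])o4)cc3F)cnc2c1` carries a methoxy on the core and a fluoro on the central ring. In a functional assay on AGS cells (Homo sapiens) for antiproliferative activity, read by CCK-8 assay, with a stated time of 72 h (a lower number here means a stronger inhibitor, a higher number a weaker inhibitor), compound 1 gives 1240 nM. In this assay compound 2 gives 700 nM; the two numbers lie within the usual scatter of each other, so no order between compound 1 and compound 2 can be read from them.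

Compound 3 `COc1ccn2c(-c3ccc(NC(=O)c4ccc([N+](=O)[O-])o4)cc3OC)cnc2c1` has not yet been measured. It differs from compound 2 in one place: methoxy in place of fluoro on an aromatic carbon. Among the compounds with values here, no pair of measured compounds shows the effect of this change, and the two measured numbers give no guide to the direction. A step of modest size, within or close to the scatter, is expected in either direction; on balance a slightly higher number is assumed, giving an expected step of a 1.3-fold higher number from compound 2 to compound 3 (0.11 log units; within the scatter). For compound 3 in this assay the estimate is 900 nM, with a range from 350 nM to 2500 nM.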

Compound 3, half-maximal inhibitory concentration: > 20000 nM
Compound 3 gave a limit, no number; the forecaster's own chance of this, stated with the estimate: 5%; middle value at least 22-fold (1.34 log units) from the limit.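

In this assay, the carbon of the central ring that lies ortho to a large group and meta to a large group is far from indifferent: methoxy in place of fluoro gives an at least 28-fold higher number from compound 2 to compound 3 (1.45 log units; beyond the scatter). Compound 1 and compound 2 lie within the scatter of each other and differ in more than one place; they showed nothing about this position, whereas this single exchange moves the read-out well beyond the scatter. Compound 3 carries a limit of the assay and not a number, and the step therefore gives only a lower bound on the true size of the change: the limit of > 20000 nM in this assay, at which 1 of the 3 values shown sits.

The compounds shown leave open whether the step is specific to methoxy or would follow from any group other than fluoro on this carbon, as only these two groups appear there; a hydrogen, a methyl or a hydroxyl on the same carbon would bear on that question. As far as these compounds go, it also remains open whether the same exchange would have a comparable effect with the pyrrolidine of compound 1 on the core in place of the methoxy there.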